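From 3-bromobenzyl to 2,4-dichlorobenzyl in a cytotoxicity series

The source may hold more compounds than are shown below. What is called first, only, known or untested is meant among the compounds shown, and "the series" means these compounds.

compound 1 `O=C(Nc1ccc(Nc2ncnc3c2cnn3-c2ccccc2)cc1)Nc1cccc(Cl)c1` gives 4200 nM
compound 2 `O=C(Nc1ccc(Nc2ncnc3c2cnn3-c2ccc(Cl)cc2)cc1)Nc1ccccc1Cl` gives 9050 nM
compound 3 `O=c1sc2cc(Nc3ncnc4c3cnn4-c3ccccc3)ccc2n1Cc1cccc(Br)c1` gives 46100 nM

All three values come from a functional assay on MCF7 cells (Homo sapiens) for cytotoxicity, read by sulforhodamine B assay, with a stated time of 72 h (a higher number here means a weaker inhibitor, a lower number a stronger inhibitor), and compound 3 is the weakest of them, with its number beyond the scatter from those of both other compounds. Among the compounds with values here, compound 4 `O=c1sc2cc(Nc3ncnc4c3cnn4-c3ccccc3)ccc2n1Cc1ccc(Cl)cc1Cl` has 2,4-dichlorophenyl in place of 3-bromophenyl on a saturated chain carbon bound to an aromatic nitrogen as its only difference from compound 3. Within the data shown here, no measured pair differs in just one place, so nothing shows directly how large this step should be. Among the measured compounds shown here, with compound 3 at 46100 nM at the top of the numbers so far, a slightly lower number is expected, with no step beyond the scatter. The expected step is a 1.5-fold lower number from compound 3 to compound 4 (0.19 log units; within the scatter) (an estimate only). In this assay the estimate for compound 4 is 30000 nM (expected range 10000 nM to 80000 nM).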

Compound 4, half-maximal inhibitory concentration: 44000 nM
Estimate against measurement, compound 4: 1.5-fold (0.17 log units) below; the range from low to high includes it.
By their numbers in this assay, from the lowest: compound 1; then compound 2; then compounds 4 and 3 (each within the scatter of the next).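

In this assay, within the data shown here, the change from 3-bromophenyl to 2,4-dichlorophenyl on a saturated chain carbon bound to an aromatic nitrogen gives a 1.0-fold lower number from compound 3 to compound 4 (0.02 log units; within the scatter) and so leaves the number within the scatter, which no earlier pair could show. At this place, these two halogenated phenyl groups cannot be told apart in this assay. Nothing available accounts for this result. The compounds shown leave open whether an unsubstituted phenyl, a carboxylic acid or an amine at this place would shift the number beyond the scatter.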